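The compounds below may be only part of what the source reports. "The series", "measured", "known", "first", "only" and "open" are said of these compounds alone.

Measured compounds:

compound 1, `O=C(CCCl)Nc1ccc(S(=O)(=O)Oc2ccccc2I)cc1`: 4200 nM
compound 2, `CC(C)c1ccccc1OS(=O)(=O)c1ccc(NC(=O)CCCCl)cc1`: 3800 nM

In a functional assay on HT-1080 cells (Homo sapiens) for antiproliferative activity, read by sulforhodamine B assay, with a stated time of 48 h (a lower number here means a stronger inhibitor, a higher number a weaker inhibitor), compound 2 gives 3800 nM, the lowest of the two numbers recorded. Compound 1 gives 4200 nM in this assay, and the gap between the two is within the scatter, so the two compounds cannot be told apart on these data. Going by the values given here, compound 1 and compound 2 differ in more than one place, so no single step between measured compounds is available to guide an expectation.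

Compound 3, `O=C(CCCCl)Nc1ccc(S(=O)(=O)Oc2ccccc2I)cc1`, is reached from compound 2 by one change: iodo in place of isopropyl on an aromatic carbon. The group that enters sits ortho to a large group on a six-membered aromatic ring of carbon only. Since compound 1 already carries iodo at that place and sits within the scatter of compound 2, the step of a 1.1-fold higher number from compound 2 to compound 3 (0.02 log units; within the scatter) is expected to stay within the scatter, with no clear direction. Compound 3 is therefore estimated at 4000 nM in this assay, with a range from 1500 nM to 10000 nM.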

Compound 3, half-maximal inhibitory concentration: 12000 nM
For compound 3 the middle estimate is 3.0-fold (0.48 log units) below the measured one; measured number above the stated range.
By their numbers in this assay, from the lowest: compounds 2 and 1 (each within the scatter of the next); then compound 3.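

In this assay, iodo in place of isopropyl on the aromatic carbon ortho to a large group gives a 3.2-fold higher number from compound 2 to compound 3 (0.50 log units; beyond the scatter) and so counts as a real, if modest, change at this place, something the two earlier compounds, which differ in more than one place, could not show. The chain also counts: with iodo held in place, chloromethyl in place of chloro on the saturated chain carbon, two bonds along the chain from a carbonyl carbon, gives a 2.9-fold higher number from compound 1 to compound 3 (0.46 log units; beyond the scatter) and this modest step runs in the same direction. Nothing available here accounts for either step.

The compounds shown leave open how bromo, methoxy or an amine would read on that aromatic carbon, and so whether iodo or isopropyl is the exception among such groups. They also leave open whether a longer chain carrying the chlorine would continue the same direction, and whether isopropyl would keep its lower number on the shorter chain of compound 1.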